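The compounds below may be only part of what the source reports. "The series", "measured", "known", "first", "only" and "open" are said of these compounds alone.

Compound 1 `CCCCCCC(C)(O)CC(=O)O[C@H](CC=C(C)C)C1=CC(=O)c2c(O)ccc(O)c2C1=O` is tested in a functional assay on HeLa cells (Homo sapiens) for cytotoxicity, read by MTT assay; on this read-out lower numbers stand for stronger inhibition and higher numbers for weaker inhibition. In this assay compound 1 gives only a limit, > 100000 nM. Its two measured partners do reach numbers: compound 2 `CC(C)=CC[C@@H](OC(=O)CC(O)c1ccccc1)C1=CC(=O)c2c(O)ccc(O)c2C1=O` gives 44500 nM in this assay, and compound 3 `CC(C)=CC[C@@H](OC(=O)CC(C)(O)C(C)C)C1=CC(=O)c2c(O)ccc(O)c2C1=O` gives 27700 nM. The step of an at least 2.2-fold lower number from compound 1 to compound 2 (0.35 log units; beyond the scatter) and the step of an at least 3.6-fold lower number from compound 1 to compound 3 (0.55 log units; beyond the scatter) both move off the limit, whereas the step of a 1.6-fold lower number from compound 2 to compound 3 (0.21 log units; within the scatter) does not leave the scatter. Compound 4 `CCCCC(C)(O)CC(=O)O[C@H](CC=C(C)C)C1=CC(=O)c2c(O)ccc(O)c2C1=O` differs from compound 1 by hydrogen in place of ethyl on a saturated chain carbon, five bonds along the chain from an oxygen on a saturated carbon. The step of an at least 3.6-fold lower number from compound 1 to compound 3 (0.55 log units; beyond the scatter) bears on this most directly: there too the hexyl was shortened, only further, so a smaller move in the same direction is expected here. Compound 4 is therefore expected to give about 60000 nM in this assay, between 25000 nM and 150000 nM, the step of an at least 1.6-fold lower number from compound 1 to compound 4 (0.22 log units; that floor lies within the scatter) being the estimate.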

Compound 4, half-maximal inhibitory concentration: 60600 nM
For compound 4 the middle estimate is 1.0-fold (0.00 log units) below the measured one, and the stated range covers the measured number.
By their numbers in this assay, from the lowest: compounds 3, 2 and 4 (each within the scatter of the next, the first and the last beyond it). At a limit, above all of these: compound 1.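

Hydrogen in place of ethyl brings a measurable number in this assay, an at least 1.6-fold lower number from compound 1 to compound 4 (0.21 log units; that floor lies within the scatter), but the true size of this change stays unknown, as its starting point is only a limit: the limit of > 100000 nM in this assay, at which 1 of the 4 values shown sits. Butyl is not equivalent to isopropyl on this carbon, a 2.2-fold higher number from compound 3 to compound 4 (0.34 log units; beyond the scatter). Replacing the whole side group with hydroxy(phenyl)methyl, by contrast, does not leave the scatter, a 1.4-fold higher number from compound 2 to compound 4 (0.13 log units; within the scatter).

The compounds shown leave open how a propyl chain, an octyl chain or an amine would read at this position.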